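The source may report more compounds than this note shows. Statements on the series, on what has been measured and on what is new or still open speak of the compounds shown alone.

Of the compounds shown here, three share one core and have been tested in a functional assay on MOLT-4 cells (Homo sapiens), with a stated time of 72 h; a lower number here means a stronger inhibitor, a higher number a weaker inhibitor. Compound 1, `O=C1Nc2ccc(Cl)cc2/C1=N/NC(=S)Nc1ccc(Cl)cc1`, gives 64000 nM. Compound 2, `Cc1ccc(CN2C(=O)/C(=N\NC(=S)Nc3ccc(Cl)cc3)c3cc(Cl)ccc32)cc1`, gives 5800 nM, and compound 3, `O=C1/C(=N\NC(=S)Nc2ccc(Cl)cc2)c2cc(Cl)ccc2N1Cc1ccc(F)cc1`, gives 48000 nM. Compound 2 has the lowest number of the three, and both of its steps lie beyond the scatter: an 8.3-fold higher number from compound 2 to compound 3 (0.92 log units; beyond the scatter), and from compound 1 the change is an 11-fold lower number from compound 1 to compound 2 (1.04 log units; beyond the scatter). The other step, a 1.3-fold lower number from compound 1 to compound 3 (0.12 log units; within the scatter), stays within the scatter.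

Compound 4, `Cc1ccc(CN2C(=O)/C(=N\NC(=S)Nc3ccc(Cl)cc3)c3cc(Br)ccc32)cc1`, is not yet measured. It differs from compound 2 in one place: bromo in place of chloro on an aromatic carbon. None of the three measured steps touches this spot. Those steps concern the 4-methylbenzyl and 4-fluorobenzyl groups on the ring nitrogen and the swap of fluoro for methyl there; the halogen on the fused ring is chloro in every measured compound. There is thus no measured guide for this change, and the expectation rests on the closeness of chloro and bromo as single heavy atoms without donors or acceptors. The expected step in this assay is therefore no change at the digits printed from compound 2 to compound 4 (within the scatter), none beyond the scatter. Compound 4 is estimated at 5800 nM, with a range from 2500 nM to 14000 nM.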

Compound 4, half-maximal inhibitory concentration: 74000 nM
Beside the measured number, compound 4's estimate is 13-fold (1.11 log units) below it, outside the stated range (above it).
By their numbers in this assay, from the lowest: compound 2; then compounds 3, 1 and 4 (each within the scatter of the next).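

In this assay, the position on the six-membered aromatic ring of carbon only carries chloro in every earlier compound, so its sensitivity could not be seen until now. Bromo in place of chloro gives a 13-fold higher number from compound 2 to compound 4 (1.11 log units; beyond the scatter) and thus shows that this spot is far from indifferent, even though the exchange only replaces one halogen atom with another and neither group has a hydrogen-bond donor or acceptor. This large step shows that a single-atom change here can matter as much as a whole benzyl group on the ring nitrogen, as seen in the equally large an 11-fold lower number from compound 1 to compound 2 (1.04 log units; beyond the scatter) in the same series, but no measurement offered here explains why the number moves at this position.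

The compounds shown leave open how bromo behaves when the ring nitrogen carries hydrogen or 4-fluorobenzyl, so it cannot be told whether this step belongs to the halogen alone or to its pairing with 4-methylbenzyl. Also open, going by these compounds, is how fluoro, a methoxy group or an amine at this spot would compare with chloro and bromo.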